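Nitro for Chloro on a Weakly Cytotoxic Scaffold

A few compounds are considered here, and "the series" means these few. Any claim that something is new, unique, unknown or untested is made for them only; others in the source may bear on it.

Compound 1 `CCn1c(/C=C2/C(=O)Nc3ccc(C)cc32)nc2ccccc21` gives 38600 nM in a functional assay on PC-3 cells (Homo sapiens) for cytotoxicity, read by MTT assay, with a stated time of 48 h; on this read-out higher numbers stand for weaker inhibition and lower numbers for stronger inhibition. Compound 2 `CCn1c(/C=C2/C(=O)Nc3ccc(Cl)cc32)nc2ccccc21` gives only the limit > 50000 nM in this assay.

Compound 2 therefore stands at the edge of what this assay can report: its value is a limit, not a number, as recorded in the limit of > 50000 nM in this assay, at which 1 of the 2 values shown sits. Compound 3 `CCn1c(/C=C2/C(=O)Nc3ccc([N+](=O)[O-])cc32)nc2ccccc21` differs from compound 2 by nitro in place of chloro on an aromatic carbon. Going by the values given here, only one measured step bears on this change, an at least 1.2-fold higher number from compound 1 to compound 2 (0.11 log units; that floor lies within the scatter), which exchanged the group at the same aromatic carbon; no measured step involves a nitro group. Compound 3 is therefore expected to stay in the same weak region, with a step of a number no higher from compound 2 to compound 3 (the limit leaves the size open) expected to lie within the scatter. The value of compound 3 in this assay is estimated at 50000 nM, between 20000 nM and 150000 nM, with a real chance that only a limit is reported again.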

Compound 3, half-maximal inhibitory concentration: 40100 nM
Beside the measured number, compound 3's estimate is 1.2-fold (0.10 log units) above it; low and high end bracket the measured number.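

In this assay the step of a 1.0-fold higher number from compound 1 to compound 3 (0.02 log units; within the scatter) shows that nitro and methyl at this aromatic carbon cannot be told apart, something the earlier pair could not show because it lacked a number on one side. Against chloro, the change reads as an at least 1.2-fold lower number from compound 2 to compound 3 (0.09 log units; that floor lies within the scatter) and leaves the true size of the step open, so it shows no firm difference between nitro and chloro. Compound 2 gives a limit and not a number: the limit of > 50000 nM in this assay, at which 1 of the 3 values shown sits.

Methyl, chloro and nitro all leave the compounds in the same weak region, so it stays open whether any group at this carbon can move the number beyond the scatter. The compounds shown do not say what an amine, a carboxylic acid or a longer chain at this carbon would do.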